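Ring substitution and cytotoxic growth inhibition in a small series

The source may hold more compounds than are shown below. What is called first, only, known or untested is meant among the compounds shown, and "the series" means these compounds.

Measured so far in a functional assay on PCO3 cells (Homo sapiens) for cytotoxicity, read by sulforhodamine B assay; a lower number here means a stronger inhibitor of growth, a higher number a weaker inhibitor of growth:
compound 1 `CC1=CC[C@@H]([C@@](C)(O)CCCC(C)(C)NC(=S)N/N=C\c2ccccc2)CC1` gives 36200 nM.
compound 2 `COc1ccc(/C=N\NC(=S)NC(C)(C)CCC[C@](C)(O)[C@@H]2CC=C(C)CC2)cc1` gives 76100 nM.
compound 3 `CC1=CC[C@@H]([C@@](C)(O)CCCC(C)(C)NC(=S)N/N=C\c2ccccc2[N+](=O)[O-])CC1` gives only a limit of the assay, > 100000 nM.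

Compound 1 stands lowest of the two numbers shown; the nearest is compound 2, with a 2.1-fold higher number from compound 1 to compound 2 (0.32 log units; beyond the scatter). Compound 3 sits at the limit of > 100000 nM in this assay, at which 1 of the 3 values shown sits, so its step from compound 1 is known only as a floor. Two steps alter the unsubstituted aromatic ring of compound 1: methoxy in place of hydrogen on an aromatic carbon, a 2.1-fold higher number from compound 1 to compound 2 (0.32 log units; beyond the scatter), and nitro in place of hydrogen on an aromatic carbon, an at least 2.7-fold higher number from compound 1 to compound 3 (0.44 log units; beyond the scatter). Between the two substituted compounds, an at least 1.3-fold higher number from compound 2 to compound 3 (0.11 log units; that floor lies within the scatter).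

Compound 4 `CC1=CC[C@@H]([C@@](C)(O)CCCC(C)(C)NC(=S)N/N=C\c2ccc(Cl)cc2)CC1` has not yet been measured in this assay. It differs from compound 1 by chloro in place of hydrogen on an aromatic carbon. Both measured substitutions on that ring moved the number upward, one modestly and one at least modestly, and nothing shown moved it downward. A modest rise in this assay is therefore expected for compound 4, as a 1.5-fold higher number from compound 1 to compound 4 (0.18 log units; within the scatter). Compound 4 is estimated at 55000 nM, with a range from 28000 nM to 110000 nM, and some chance that only a limit is reported.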

Compound 4, concentration for total growth inhibition: 22700 nM
The estimate for compound 4 lay 2.4-fold (0.38 log units) above the measured number; measured number below the stated range.
By their numbers in this assay, from the lowest: compounds 4 and 1 (each within the scatter of the next); then compound 2. At a limit, above all of these: compound 3.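

The chloro group of compound 4, para to a large group, is the one ring substitution shown that leaves the number within the scatter of the unsubstituted compound in this assay, with a 1.6-fold lower number from compound 1 to compound 4 (0.20 log units; within the scatter), whereas chloro in place of methoxy gives a 3.4-fold lower number from compound 2 to compound 4 (0.53 log units; beyond the scatter), so the upward trend set by compounds 2 and 3 does not extend to compound 4. The step 4-chlorophenyl in place of 2-nitrophenyl gives an at least 4.4-fold lower number from compound 3 to compound 4 (0.64 log units; beyond the scatter), which also changes the place of the substituent and therefore does not isolate the group. Compound 3 is reported only as a limit, and its step to compound 4 is a floor: the limit of > 100000 nM in this assay, at which 1 of the 4 values shown sits.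

Still open, from the compounds shown here alone, is whether bromo, trifluoromethyl or an amine on the same ring carbon would stay level with compound 1 or give a higher number, as methoxy does in compound 2. Also open, going by these compounds, is whether chloro on another carbon of the ring would give a number level with compound 4, since all the chloro evidence here comes from one place.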